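Removing a methoxy group from a urea-linked indole thioether

The compounds below may be only part of what the source reports. "The series", "measured", "known", "first", "only" and "open" are said of these compounds alone.

Three compounds share a core in which an indole thioether hangs from a pyrimidine that also carries a urea. Compound 1 `COc1ccc(NC(=O)Nc2nc(Sc3c[nH]c4ccccc34)cc(N3CCN(Cc4ccccc4)CC3)n2)cc1` places a benzylpiperazine on that core and a methoxy group on the urea's phenyl ring. In a functional assay on MDA-MB-231 cells (Homo sapiens) for inhibition, with a stated time of 72 h (on this read-out higher numbers stand for weaker inhibition and lower numbers for stronger inhibition), compound 1 gives 8920 nM. Compound 3 `COc1ccc(NC(=O)Nc2nc(Sc3c[nH]c4ccccc34)cc(N3CCCCC3)n2)cc1`, with a piperidine instead, gives 7260 nM, and compound 2 `Cc1cc(Cl)ccc1NC(=O)Nc1nc(NC2CC2)cc(Sc2c[nH]c3ccccc23)n1`, carrying a cyclopropylamine and a chloro-methyl-substituted phenyl, gives 14600 nM. Compound 1 holds the second highest of these three numbers, yet all three sit within the usual scatter of one another, so no order among them can be read.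

Compound 4 `O=C(Nc1ccccc1)Nc1nc(Sc2c[nH]c3ccccc23)cc(N2CCN(Cc3ccccc3)CC2)n1` differs from compound 1 in one place: hydrogen in place of methoxy on an aromatic carbon. Going by the values given here, no measured pair here shows the effect of such a change, so the expectation rests on the narrow spread of the measured values. The step from compound 1 to compound 4 is expected to be small, a 1.1-fold higher number from compound 1 to compound 4 (0.03 log units; within the scatter), not beyond the scatter in either direction. Compound 4 is therefore estimated at 9500 nM, with a likely range from 4000 nM to 22000 nM.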

Compound 4, half-maximal inhibitory concentration: 10200 nM
Beside the measured number, compound 4's estimate is 1.1-fold (0.03 log units) below it; the range from low to high includes it.
By their numbers in this assay, from the lowest: compounds 3, 1, 4 and 2 (each within the scatter of the next).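

Going by these compounds alone, this pair is the first comparison here that isolates a single place, the aromatic carbon of the urea's phenyl ring that carries the methoxy group. In this assay, replacing methoxy with hydrogen gives a 1.1-fold higher number from compound 1 to compound 4 (0.06 log units; within the scatter) and so no readable difference, which means that on the benzylpiperazine core of compound 1, this read-out does not distinguish between the 4-methoxyphenyl and phenyl forms. Nothing available explains this result.

From the compounds shown here alone, the pair tests only methoxy and hydrogen, so it remains open whether a different group on this carbon, such as an amine or a carboxylic acid, would shift the number beyond the scatter. Going by these compounds, it also remains open whether the same swap would give so small a step on the piperidine core of compound 3.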